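Swapping Butyl for Nitro on a Shared Core

This account rests on a few compounds, and the source may have more. Where it says the series, first, only, none or still open, it means among the compounds named here.

Of the compounds shown here, three built on one shared core have been tested in a functional assay on SW480 cells (Homo sapiens) for inhibition, read by CCK-8 assay, with a stated time of 72 h, tested at 20 uM; a lower number here means less inhibition of growth, a higher number more inhibition of growth at the concentration tested. Compound 1 `CCOC(=O)/C=C1/C(=O)Nc2ccccc21` gives 78.3%. Compound 2 `CCCCc1ccc2c(c1)/C(=C\C(=O)OC(C)(C)C)C(=O)N2` gives 78.3%, level with compound 1 at the digits shown, and together these are the highest of the three numbers, though the gap between them lies within the usual scatter. Compound 3 `CC(C)(C)OC(=O)/C=C1/C(=O)Nc2c(Cl)cccc21` gives 78%, a number only slightly lower than that of compound 2 and again within the scatter, so none of the three can be told apart from the others.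

The next compound, compound 4 `CC(C)(C)OC(=O)/C=C1/C(=O)Nc2ccc([N+](=O)[O-])cc21`, differs from compound 2 in one place: nitro in place of butyl on an aromatic carbon. Among the measured compounds shown here, no pair among the measured compounds differs in just one place, so no single step has been measured. Compound 1 at 78.3%, compound 2 at 78.3% and compound 3 at 78% carry different ester and ring groups yet all lie within the scatter of one another. On that basis the expected step is a number 3.3 percentage points lower from compound 2 to compound 4 (within the scatter), none beyond the scatter. Compound 4 is therefore estimated at 75%, within a range from 55% to 90%.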

Compound 4, percent growth inhibition at one concentration: 77.9%
Compound 4: the middle estimate sits 2.9 percentage points below what was measured, and the stated range covers the measured number.
By their numbers in this assay, from the lowest: compounds 4, 3, 1 and 2 (each within the scatter of the next).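

Among the compounds shown here, the first single change on the shared core, nitro in place of butyl on an aromatic carbon, gives in this assay a number 0.4 percentage points lower from compound 2 to compound 4 (within the scatter). This position, meta to a fused ring and para to a fused ring, can therefore carry either a chain of four carbons with no hydrogen-bond acceptors or a nitro group with two, and the growth-inhibition read-out at this single concentration does not tell the two compounds apart. Nothing measured here explains why these two different groups read alike.

The compounds shown leave open whether an amine or a carboxylic acid on this same carbon would also read alike. On these data alone, it also remains open whether compound 2 and compound 4 would still match at lower concentrations, where a full dose-response curve could separate them.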